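Ethyl to methoxy in a sulfonamide series

A few compounds are considered here, and "the series" means these few. Any claim that something is new, unique, unknown or untested is made for them only; others in the source may bear on it.

- compound 1 `CCc1cccc(NS(=O)(=O)c2ccc(N3CCNC3=O)cc2)c1`: 730 nM
- compound 2 `Cc1cc(C)cc(NS(=O)(=O)c2ccc(N3CCNC3=O)cc2)c1`: 430 nM
- compound 3 `COc1cc(NS(=O)(=O)c2ccc(N3CCNC3=O)cc2)cc(OC)c1`: 700 nM

In a functional assay on DU-145 cells (Homo sapiens) for antiproliferative activity, read by sulforhodamine B assay, with a stated time of 48 h (a lower number here means a stronger inhibitor, a higher number a weaker inhibitor), compound 1 gives 730 nM. This value lies within the scatter of the values of the other two compounds, so no order can be read among the three.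

Compound 4 `COc1cccc(NS(=O)(=O)c2ccc(N3CCNC3=O)cc2)c1` has not yet been measured. It differs from compound 1 as follows: methoxy in place of ethyl on an aromatic carbon. In words, it has methoxy in place of ethyl on an aromatic carbon, turning 3-ethylphenyl into 3-methoxyphenyl.

Going by the values given here, the one measured step at this part of the structure is a 1.7-fold lower number from compound 1 to compound 2 (0.23 log units; within the scatter), and it stays within the scatter. Compound 3, which also carries methoxy, gives 700 nM, within the scatter of compound 1. No measured change here has moved the number beyond the scatter, so no shift beyond it is expected in this assay for this swap.

The estimated step is a 1.2-fold lower number from compound 1 to compound 4 (0.09 log units; within the scatter). For compound 4 the expected value is 600 nM, with an estimated range from 300 nM to 1200 nM.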

Compound 4, half-maximal inhibitory concentration: 650 nM
Beside the measured number, compound 4's estimate is 1.1-fold (0.03 log units) below it; the measured number falls inside the stated range.
By their numbers in this assay, from the lowest: compounds 2, 4, 3 and 1 (each within the scatter of the next).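

In this assay, methoxy in place of ethyl gives a 1.1-fold lower number from compound 1 to compound 4 (0.05 log units; within the scatter), so at this position on the aromatic ring the entering hydrogen-bond acceptor comes with no shift beyond the scatter. Going by these compounds alone, the neighbouring changes stay within the scatter too: hydrogen in place of methoxy gives a 1.1-fold lower number from compound 3 to compound 4 (0.03 log units; within the scatter), and 3-methoxyphenyl in place of 3,5-dimethylphenyl gives a 1.5-fold higher number from compound 2 to compound 4 (0.18 log units; within the scatter), so the single methoxy compound does not separate from any of the other three compounds. Nothing measured here offers a reason for this flat result.

As far as these compounds go, whether an amine, a carboxylic acid or a longer chain at this position would move the number beyond the scatter remains open. So does whether the swap of ethyl for methoxy would stay this quiet on a different cell line.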